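Nitro added para on the acetophenone-derived thiosemicarbazone

This account rests on a few compounds, and the source may have more. Where it says the series, first, only, none or still open, it means among the compounds named here.

Measured so far:
compound 1, `CC1=CC[C@H](C(C)(C)NC(=S)N/N=C/c2cccc(Cl)c2)CC1`: 26900 nM
compound 2, `CC1=CC[C@H](C(C)(C)NC(=S)N/N=C/c2ccccc2[N+](=O)[O-])CC1`: > 100000 nM
compound 3, `CC1=CC[C@H](C(C)(C)NC(=S)N/N=C(\C)c2ccccc2)CC1`: > 100000 nM

Of the compounds shown here, three sharing one core have been tested in a functional assay on 786-0 cells (Homo sapiens) for inhibition, read by sulforhodamine B assay, with a stated time of 48 h; a higher number here means a weaker inhibitor of growth, a lower number a stronger inhibitor of growth. Compound 1 gives 26900 nM in this assay. For compound 2 this assay returns only a limit, > 100000 nM, not a number. For compound 3 the result is likewise a limit, > 100000 nM. So compound 3 stands at the ceiling of this assay, a point where two of the three values sit (the limit of > 100000 nM in this assay, at which 2 of the 3 values shown sit); only compound 1 falls under it with a measured number.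

Compound 4, `CC1=CC[C@H](C(C)(C)NC(=S)N/N=C(\C)c2ccc([N+](=O)[O-])cc2)CC1`, is not yet measured. It differs from compound 3 by nitro in place of hydrogen on an aromatic carbon, in words: nitro in place of hydrogen on an aromatic carbon, para to a large group. Going by the values given here, no step between two measured compounds is known, so the size of this change cannot be read from the data. Given that compound 3 gives > 100000 nM, only a limit, no step can be computed; the expectation is for no change beyond the scatter, an at least 1.1-fold lower number from compound 3 to compound 4 (0.04 log units; that floor lies within the scatter), with a real chance that this assay again returns a limit. Compound 4 is therefore expected to give about 90000 nM, somewhere between 25000 nM and 300000 nM.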

Compound 4, concentration for total growth inhibition: > 100000 nM
Compound 4 gave a limit, no number; the forecaster's own chance of this, stated with the estimate: 55%; middle value at least 1.1-fold (0.04 log units) from the limit.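

On these data alone, compound 3 and compound 4 both return only a limit in this assay, so no step can be read between them, and the effect of nitro in place of hydrogen on an aromatic carbon stays unknown. Both sit at the assay's ceiling: the limit of > 100000 nM in this assay, at which 3 of the 4 values shown sit. The compounds shown leave open whether this change affects growth inhibition at all.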